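Compound 2 to compound 3: one more ring nitrogen

The compounds below may be only part of what the source reports. "The series", "measured", "known", "first", "only" and "open" are said of these compounds alone.

In a functional assay on MDA-MB-231 cells (Homo sapiens) for antiproliferative activity, with a stated time of 72 h (a lower number here means that less compound is needed, a higher number that more compound is needed for the effect), compound 1 `O=C(O)c1ccc(N(Cc2ccc(C3CCCCC3)cc2)C(=O)[C@H]2CCN2S(=O)(=O)c2c(F)c(F)c(F)c(F)c2F)c(F)c1` gives > 10000 nM, which is a limit of the assay and not a number. Among the compounds with values here, compound 2 `O=C([C@H]1CCN1S(=O)(=O)c1c(F)c(F)c(F)c(F)c1F)N(Cc1ccc(C2CCCCC2)cc1)c1ccc2c(=O)[nH]ccc2c1` gives 1400 nM, the only actual number so far in this short series.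

The next analogue is compound 3 `O=C([C@H]1CCN1S(=O)(=O)c1c(F)c(F)c(F)c(F)c1F)N(Cc1ccc(C2CCCCC2)cc1)c1ccc2c(=O)[nH]ncc2c1`, which has a group of 11 heavy atoms (8 carbon, 2 nitrogen, 1 oxygen; one six-membered aromatic ring of carbon only, one six-membered aromatic ring with 2 hetero atoms) in place of a group of 11 heavy atoms (9 carbon, 1 nitrogen, 1 oxygen; one six-membered aromatic ring of carbon only, one six-membered aromatic ring with 1 hetero atom), on an amide-type nitrogen. The rest of the structure is unchanged, including the group on the sulfonyl and the cyclohexyl-bearing benzyl group.

Within the data shown here, only one measured step bears on this change: an at least 7.1-fold lower number from compound 1 to compound 2 (0.85 log units; beyond the scatter). It lies beyond the scatter, and only a lower bound on its size is known because of the limit of > 10000 nM in this assay, at which 1 of the 2 values shown sits. That step replaced a group with a different ring set, so it shows that the group on the amide-type nitrogen matters in this assay. It does not size a swap of one ring carbon for nitrogen.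

No step beyond the scatter is therefore expected, with only a slight lean towards a higher number: the estimate is a 1.4-fold higher number from compound 2 to compound 3 (0.15 log units; within the scatter). For compound 3, the estimated value is 2000 nM, with an expected range of 700 nM to 6000 nM.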

Compound 3, half-maximal effective concentration: 1600 nM
For compound 3 the middle estimate is 1.3-fold (0.10 log units) above the measured one, within the range that was stated.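

In this assay, the second ring nitrogen leaves no readable mark: a 1.1-fold higher number from compound 2 to compound 3 (0.06 log units; within the scatter). The group that enters on the amide-type nitrogen, with its six-membered aromatic ring with 2 hetero atoms and one more hydrogen-bond acceptor by count, therefore serves as well as the group of compound 2, so this position tolerates at least this one swap of a ring carbon for nitrogen. The step from the group of compound 1 now appears with a second group, an at least 6.2-fold lower number from compound 1 to compound 3 (0.79 log units; beyond the scatter), which makes two groups with a second fused aromatic ring that lie beyond the scatter from it. The value of compound 1 is a limit and not a number, so both steps have only a lower bound on their size: the limit of > 10000 nM in this assay, at which 1 of the 3 values shown sits.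

The compounds shown leave open what a methyl group in place of the amide hydrogen of the entering group would do in this assay. On these data alone, it is equally open whether an amine in place of the carbonyl of that group would hold the value, since the steps here do not separate the contributions of these atoms.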